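Removing a Trifluoromethyl from the Hydrazone Aryl Ring

The source may report more compounds than this note shows. Statements on the series, on what has been measured and on what is new or still open speak of the compounds shown alone.

Measured compounds:
compound 1 `Cc1nc(N(C)C(=O)NC(=O)c2c(F)cccc2F)sc1C(=O)N/N=C/c1ccccc1C(F)(F)F` gives 1.11 ug/mL
compound 2 `Cc1nc(N(C)C(=O)NC(=O)c2ccc(Cl)cc2Cl)sc1C(=O)N/N=C/c1ccc(C(F)(F)F)cc1` gives > 100 ug/mL
compound 3 `CN(C(=O)NC(=O)c1c(F)cccc1F)c1nc(C(F)(F)F)c(C(=O)N/N=C/c2ccccc2C(F)(F)F)s1` gives 26.1 ug/mL

Of the compounds shown here, three sharing one core have been tested in a functional assay on HepG2 cells (Homo sapiens) for inhibition, read by MTT assay, with a stated time of 72 h; a lower number here means a stronger inhibitor, a higher number a weaker inhibitor. Compound 1 has the lowest of the two numbers shown, and its nearest neighbour is compound 3, the change being a 24-fold higher number from compound 1 to compound 3 (1.37 log units; beyond the scatter). Compound 2 gives only a limit of this assay, not a number, a limit described as the limit of > 100 ug/mL in this assay, at which 1 of the 3 values shown sits.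

Compound 4 `Cc1nc(N(C)C(=O)NC(=O)c2c(F)cccc2F)sc1C(=O)N/N=C/c1ccccc1` is the next compound, differing from compound 1 by hydrogen in place of trifluoromethyl on an aromatic carbon. Among the compounds with values here, no measured step touches this part of the molecule: the one step, from compound 1 to compound 3, alters the core, while compound 2 differs from compound 1 in more than one place and reports only a limit. Within the data shown here, with no step bearing on this position, the expectation rests on compound 1 alone, and a small to moderate rise in number is expected, a 2.7-fold higher number from compound 1 to compound 4 (0.43 log units; beyond the scatter). Compound 4 is therefore estimated at 3 ug/mL, ranging from 0.8 ug/mL to 15 ug/mL.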

Compound 4, half-maximal inhibitory concentration: 54.3 ug/mL
Beside the measured number, compound 4's estimate is 18-fold (1.26 log units) below it; the whole stated range lies below it.
By their numbers in this assay, from the lowest: compound 1; then compound 3; then compound 4. At a limit, above all of these: compound 2.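

Taking the trifluoromethyl off the aromatic ring gives a 49-fold higher number from compound 1 to compound 4 (1.69 log units; beyond the scatter), so in this assay this position is far from indifferent to what it carries. The earlier compounds shown here showed only what a change in the core does, through a 24-fold higher number from compound 1 to compound 3 (1.37 log units; beyond the scatter), whereas this large step shows that the hydrazone aryl ring matters too, with the rest of compound 1 held fixed. Nothing measured here tells why the group counts for so much.

On these data alone, it remains open whether another group on this aromatic carbon, such as a methyl, a chlorine, a methoxy group or an amine, would serve as well as trifluoromethyl. Also open, as far as these compounds go, is how trifluoromethyl would fare elsewhere on this ring; compound 2 differs from compound 1 in more than one place, gives only a limit and cannot settle it.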